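The source may report more compounds than this note shows. Statements on the series, on what has been measured and on what is new or still open speak of the compounds shown alone.

Compound 1 `O=C(O)COc1ccc(-c2coc3cc(OCC(=O)O)ccc3c2=O)cc1` gives >> 9000 nM in an assay (Cricetulus griseus) for inhibition of aldehyde dehydrogenase, mitochondrial (Homo sapiens); on this read-out lower numbers stand for stronger inhibition and higher numbers for weaker inhibition; this is a limit of the assay, not a number.
Compound 2 `O=C(O)CCCCCCCCCCCOc1ccc2c(=O)c(-c3ccc(O)cc3)coc2c1` gives 130 nM in this assay.
Compound 3 `O=C(O)CCCCCOc1ccc2c(=O)cc(-c3ccc(O)cc3)oc2c1` gives 3500 nM in this assay.

Of the two numbers shown, compound 2 has the lowest; compound 3 sits well higher, beyond the scatter, but the two differ in more than one place, so only their values can be set side by side. Compound 4 `O=C(O)CCCCCCOc1ccc2c(=O)c(-c3ccc(O)cc3)coc2c1` is not yet measured. It differs from compound 2 in one place: carboxy in place of 5-carboxypentyl on a saturated chain carbon, six bonds along the chain from an oxygen on an aromatic ring. For the measured compounds named here, no single-change step has been measured here. Compound 3, which also carries a shorter acid chain, gives 3500 nM, so weaker inhibition is expected. The expected change is a 12-fold higher number from compound 2 to compound 4 (1.06 log units; beyond the scatter), toward weaker inhibition. Compound 4 is estimated at 1500 nM, between 400 nM and 6000 nM.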

Compound 4, half-maximal inhibitory concentration: 50 nM
Compound 4: the middle estimate sits 30-fold (1.48 log units) above what was measured, outside the stated range (below it).
By their numbers in this assay, from the lowest: compound 4; then compound 2; then compound 3. At a limit, above all of these: compound 1.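

Shortening the acid chain does not cost inhibition at this position: carboxy in place of 5-carboxypentyl gives a 2.6-fold lower number from compound 2 to compound 4 (0.41 log units; beyond the scatter) in this assay. The full length of the chain in compound 2 is therefore not needed to reach strong inhibition on this core, and the shorter chain even gives a modest gain. Nothing measured here accounts for this change.

From the compounds shown here alone, it remains open whether an amine or an amide could replace the carboxylic acid at the chain end. Also open, going by these compounds, is how chain lengths between those of compound 4 and compound 2 would compare.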